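This account rests on a few compounds, and the source may have more. Where it says the series, first, only, none or still open, it means among the compounds named here.

The measured compounds:

Compound 1, `CCc1ccn2c(CCCCO)c(Cn3c(=O)n(C4CC4)c4ccncc43)nc2c1`, gives in an ADME assay on HEp-2 cells (Homo sapiens) for cytotoxicity, read by CCK-8 assay, with a stated time of 6 days (on this read-out higher numbers stand for lower toxicity in this test and lower numbers for higher toxicity in this test), a value that is a limit of the assay, > 100000 nM.
Compound 2, `O=c1n(Cc2nc3cc(C(F)(F)F)ccn3c2CCCCO)c2cnccc2n1C1CC1`, gives in this assay a limit as well, > 100000 nM.
Compound 3, `O=C(O)c1c(Cn2c(=O)n(C3CC3)c3ccncc32)nc2cc(Cl)ccn12`, likewise gives in this assay only a limit, > 100000 nM.

Compound 3 thus stands where every measured compound stands: at the limit of > 100000 nM in this assay, at which 3 of the 3 values shown sit. Going by the values given here, no number separates it from compound 1 or compound 2, and the one step that joins two measured compounds, a step that the two limits leave unreadable from compound 1 to compound 2, is a step whose size cannot be read, since both of its ends are limits.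

Compound 4, `NC(=O)CCc1c(Cn2c(=O)n(C3CC3)c3ccncc32)nc2cc(Cl)ccn12`, has not yet been measured. Compared with compound 3 the change is 2-carbamoylethyl in place of carboxy on an aromatic carbon. Among the compounds with values here, no measured step touches this part of the shared core, and the only recorded step gives no size at all. There is therefore nothing in the measured data that would place compound 4 away from the limit shared by all three measured compounds, and no direction of change can be inferred from them.

Compound 4 is consequently expected to return a value close to 100000 nM, within 50000 nM to 200000 nM. The step of a number no higher from compound 3 to compound 4 (the limit leaves the size open) is estimated to be none beyond the scatter, with the assay most likely reporting a limit again.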

Compound 4, half-maximal cytotoxic concentration: > 100000 nM
Compound 4 ended at the assay's limit (the forecaster's own chance of this, stated with the estimate: 85%); the middle value lies on the limit itself.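

Compound 3 and compound 4 both return only a limit in this assay, so the step from carboxy to 2-carbamoylethyl has no readable size. The compounds shown leave open how any of them differs from the others in this test, and whether any structural change moves the read-out at all, as all share one limit: the limit of > 100000 nM in this assay, at which 4 of the 4 values shown sit.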